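Swapping 2-chlorophenyl for (2-methylphenyl)carbonyl on an amine nitrogen

This account rests on a few compounds, and the source may have more. Where it says the series, first, only, none or still open, it means among the compounds named here.

In a functional assay on OVCAR-3 cells (Homo sapiens) for antiproliferative activity, read by MTT assay, with a stated time of 24 h (on this read-out lower numbers stand for stronger inhibition and higher numbers for weaker inhibition), compound 1 `O=C(NNc1ccccc1Cl)c1ccccc1NS(=O)(=O)c1cnc(O)nc1O` gives 14100 nM. Among the compounds with values here, the only other measured compound, compound 2 `O=C(NNC(=O)c1ccccc1F)c1cccc(NS(=O)(=O)c2cnc(O)nc2O)c1`, gives 10800 nM. These two numbers lie within the scatter of each other, so compound 1 cannot be separated from compound 2 on this read-out.

The next compound, compound 3 `Cc1ccccc1C(=O)NNC(=O)c1ccccc1NS(=O)(=O)c1cnc(O)nc1O`, has not yet been measured. It carries (2-methylphenyl)carbonyl in place of 2-chlorophenyl on an amine nitrogen, while the rest of the core of compound 1 stays unchanged: (2-methylphenyl)carbonyl in place of 2-chlorophenyl on an amine nitrogen. Within the data shown here, no measured pair of compounds differs in one place only, so the data give no direct measure of what such a change does. Among the measured compounds shown here, the only guide is that compound 1 at 14100 nM and compound 2 at 10800 nM sit close together, which gives no reason to expect a large move. The expected step of a 1.2-fold lower number from compound 1 to compound 3 (0.07 log units; within the scatter) is therefore estimated to stay within the scatter, with no firm direction. For compound 3 the estimated value is 12000 nM, with an expected range from 5000 nM to 30000 nM.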

Compound 3, half-maximal inhibitory concentration: > 20000 nM
Compound 3: no number, only a limit (the forecaster's own chance of this, stated with the estimate: 8%); middle value at least 1.6-fold (0.22 log units) away from the limit.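

In this assay compound 3 gives > 20000 nM, which is a limit of the assay and not a number. Within the data shown here, this is the first comparison between compounds that differ in one place: (2-methylphenyl)carbonyl in place of 2-chlorophenyl on an amine nitrogen brings a carbonyl onto that nitrogen and gives an at least 1.4-fold higher number from compound 1 to compound 3 (0.15 log units; that floor lies within the scatter), so the change shows no gain in inhibition, though the printed floor of the step lies within the scatter. The size of the step, and so whether it truly exceeds the scatter, cannot be read, because the result for compound 3 rests on a limit: the limit of > 20000 nM in this assay, at which 1 of the 3 values shown sits.

Among these compounds, the single step does not separate the carbonyl from the exchange of chlorine for methyl, so it remains open what a 2-methylphenyl directly on that nitrogen would give. Also open, from the compounds shown here alone, is how this position would respond to a plain phenyl, or to a 2-chlorophenyl carbonyl, which would test the carbonyl with the chlorine kept in place.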